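Working notes on cytotoxicity: from compound 2 to compound 4

The compounds below may be only part of what the source reports. "The series", "measured", "known", "first", "only" and "open" are said of these compounds alone.

Measured so far:
compound 1 `CS(=O)(=O)c1ccc(C(=O)N2CCC(C(=O)N3CCN(c4ccc(F)cc4)CC3)CC2)cc1[N+](=O)[O-]` — > 27000 nM
compound 2 `CS(=O)(=O)c1ccc(C(=O)NCCCC(=O)N2CCC(c3ccccc3)CC2)cc1[N+](=O)[O-]` — > 27000 nM
compound 3 `CS(=O)(=O)c1ccc(C(=O)NCCC(=O)N2CCc3ccccc32)cc1[N+](=O)[O-]` — > 27000 nM

In an ADME assay on HepG2 cells (Homo sapiens) for cytotoxicity, read by CellTiter-Glo and ATP content, with a stated time of 72 h (on this read-out higher numbers stand for an effect only at larger amounts of compound and lower numbers for an effect already at smaller amounts), compound 1 gives > 27000 nM, which is a limit of the assay and not a number. Compound 2 gives > 27000 nM in this assay, again a limit. Compound 3 gives > 27000 nM in this assay, also a limit. Compound 2 therefore stands where the whole series stands so far: the limit of > 27000 nM in this assay, at which 3 of the 3 values shown sit. Among the measured compounds shown here, since every value is a limit, no step between measured compounds can be drawn, and nothing separates the three compounds from one another on this read-out.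

Compound 4 `CC1CCN(C(=O)CCCNC(=O)c2ccc(S(C)(=O)=O)c([N+](=O)[O-])c2)CC1` has not been measured in this assay. It differs from compound 2 in a single place: methyl in place of phenyl on a saturated ring carbon. The series gives no value away from the limit, so there is no basis for expecting movement in either direction. The expected step in this assay is a number no higher from compound 2 to compound 4 (the limit leaves the size open), none beyond the scatter. Compound 4 is estimated at 27000 nM, with a range from 14000 nM to 60000 nM, and the most likely outcome is that this assay again reports only a limit for compound 4.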

Compound 4, half-maximal effective concentration: > 27000 nM
Compound 4: a limit, no number; the forecaster's own chance of this, stated with the estimate: 85%; the middle value lies on the limit itself.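

In this assay compound 4 gives > 27000 nM, a limit and not a number. No step can be read from compound 2 to compound 4, since the series stands at one value: the limit of > 27000 nM in this assay, at which 4 of the 4 values shown sit.

The compounds shown leave open whether any structural change in the series brings a readable number, and how methyl in place of phenyl compares on this read-out.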